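The compounds below may be only part of what the source reports. "The series", "measured", "known", "first", "only" and "open" are said of these compounds alone.

Measured so far in a functional assay on A549 cells (Homo sapiens) for antiproliferative activity, read by MTT assay, with a stated time of 72 h; on this read-out higher numbers stand for weaker inhibition and lower numbers for stronger inhibition:
- compound 1 `NC1=NC2(CCOCC2)N(OCCCOc2ccc(F)cc2)C(N)=N1`: 1060 nM
- compound 2 `Cc1cc(C)cc(OCCCON2C(N)=NC(N)=NC23CCOCC3)c1`: 710 nM

Within the data shown here, compound 2 at 710 nM sits within the scatter of compound 1, the only other measured compound. Next is compound 3 `NC1=NC2(CCOCC2)N(OCCCOc2ccc(Cl)cc2Cl)C(N)=N1`, with 2,4-dichlorophenyl in place of 3,5-dimethylphenyl on an oxygen on a saturated carbon. Among the measured compounds shown here, the one measured step bearing on this, a 1.5-fold lower number from compound 1 to compound 2 (0.17 log units; within the scatter), changes the group at that same place and stays small. No step beyond the scatter is therefore expected in this assay. The expected step is a 1.1-fold higher number from compound 2 to compound 3 (0.05 log units; within the scatter). For compound 3 the estimate is 800 nM, with an expected range of 350 nM to 1800 nM.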

Compound 3, half-maximal inhibitory concentration: 70 nM
Beside the measured number, compound 3's estimate is 11-fold (1.06 log units) above it, and the stated range ends above it.
By their numbers in this assay, from the lowest: compound 3; then compounds 2 and 1 (each within the scatter of the next).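

In this assay, the group on this oxygen can move the number well beyond the scatter: 2,4-dichlorophenyl in place of 3,5-dimethylphenyl gives a 10-fold lower number from compound 2 to compound 3 (1.01 log units; beyond the scatter) and in place of 4-fluorophenyl gives a 15-fold lower number from compound 1 to compound 3 (1.18 log units; beyond the scatter) whereas the earlier change at this place stayed within the scatter. Both large steps come from a single entering group, so this is one observation rather than a trend. Nothing available accounts for their size.

Open: whether a phenyl carrying one chlorine keeps this gain, and whether a longer chain to the aryl ether preserves it.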